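Benzyl group change from compound 3 to compound 4

This account rests on a few compounds, and the source may have more. Where it says the series, first, only, none or still open, it means among the compounds named here.

Values in a functional assay on MDA-MB-231 cells (Homo sapiens) for cytotoxicity, read by MTT assay, with a stated time of 24 h; a higher number here means a weaker inhibitor, a lower number a stronger inhibitor:
- compound 1 `COc1ccc(/C=C2\CN(C(=S)SCc3cn(Cc4ccccc4F)nn3)C/C(=C\c3ccc(OC)cc3)C2=O)cc1`: > 100000 nM
- compound 2 `O=C1/C(=C/c2ccccc2F)CN(C(=S)SCc2cn(Cc3ccccc3Cl)nn2)C/C1=C\c1ccccc1F`: 100000 nM
- compound 3 `O=C1/C(=C/c2ccccc2F)CN(C(=S)SCc2cn(Cc3ccccc3F)nn2)C/C1=C\c1ccccc1F`: 57600 nM

The entry for compound 1 is a limit and not a number. Of the two numbers, compound 3 has 57600 nM and lies within the scatter of compound 2.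

Next is compound 4 `O=C1/C(=C/c2ccccc2F)CN(C(=S)SCc2cn(Cc3cccc(Cl)c3)nn2)C/C1=C\c1ccccc1F`, with 3-chlorophenyl in place of 2-fluorophenyl on a saturated chain carbon bound to an aromatic nitrogen: 2-fluorobenzyl to 3-chlorobenzyl. For the measured compounds named here, only one measured step bears on this, fluoro in place of chloro on an aromatic carbon, a 1.7-fold lower number from compound 2 to compound 3 (0.24 log units; within the scatter), so no step beyond the scatter is expected in this assay, with any drift towards a higher number. The expected step is a 1.3-fold higher number from compound 3 to compound 4 (0.11 log units; within the scatter). For compound 4 the estimated value is 75000 nM, with an expected range of 35000 nM to 130000 nM.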

Compound 4, half-maximal inhibitory concentration: > 100000 nM
Compound 4: no number, only a limit (the forecaster's own chance of this, stated with the estimate: 30%); at least 1.3-fold (0.12 log units) between middle value and limit.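

In this assay, from the compounds shown here alone, 3-chlorobenzyl in place of 2-fluorobenzyl gives an at least 1.7-fold higher number from compound 3 to compound 4 (0.23 log units; that floor lies within the scatter), so the change brings no gain at this position and its true size remains unknown. The entry for compound 4 is a limit and not a number, and it sits with the other limit in the set: the limit of > 100000 nM in this assay, at which 2 of the 4 values shown sit 3-chlorophenyl in place of 2-chlorophenyl gives a number no lower from compound 2 to compound 4 (the limit leaves the size open) and the size of this step cannot be read.

No readable step at this position yet clears the scatter. Going by these compounds, how a benzyl group bearing an amine or a carboxylic acid, or a longer chain in its place, would read remains open.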